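Ester Side Chain Swap in an Angiotensin Receptor Series

The source may hold more compounds than are shown below. What is called first, only, known or untested is meant among the compounds shown, and "the series" means these compounds.

Compound 1, `CCCc1nc(CC)c(C(=O)OCC(=O)c2ccccc2)n1Cc1ccc(-c2ccccc2S(=O)(=O)NC(=O)OCCC(C)C)cc1F`: 2 nM
Compound 2, `CCCCN(Cc1ccccc1)C(=O)c1ccc(COC(=O)c2c(CC)nc(CCC)n2Cc2ccc(-c3ccccc3-c3nn[nH]n3)cc2)cc1`: 200 nM
Compound 3, `CCCCOC(=O)NS(=O)(=O)c1ccccc1-c1ccc(Cn2c(CCC)nc(CC)c2C(=O)OCc2ccccc2C(=O)c2ccccc2)c(F)c1`: 0.9 nM

In an assay on isolated protein for binding affinity to Type-2 angiotensin II receptor (Homo sapiens) (on this read-out lower numbers stand for stronger inhibition and higher numbers for weaker inhibition), compound 1 sits second highest of the three numbers. Compound 3 is its nearest neighbour, with a lower number that lies beyond the scatter, while compound 2 gives a far higher number. Compound 4, `CCCc1nc(CC)c(C(=O)OCCCCOc2ccccc2)n1Cc1ccc(-c2ccccc2S(=O)(=O)NC(=O)OCCC(C)C)cc1F`, has not yet been measured; it differs from compound 1 in one place: 3-phenoxypropyl in place of benzoyl on a saturated chain carbon bound to an oxygen next to a carbonyl group. Compounds 1 and 3 show that this ester chain tolerates two different aromatic groups while keeping low numbers, so a small step is expected, either way or none beyond the scatter. The step from compound 1 to compound 4 is estimated as a 1.5-fold higher number from compound 1 to compound 4 (0.18 log units; within the scatter). Compound 4 is expected to give 3 nM, within 0.8 nM to 12 nM.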

Compound 4, half-maximal inhibitory concentration: 2 nM
The estimate for compound 4 lay 1.5-fold (0.18 log units) above the measured number; low and high end bracket the measured number.
By their numbers in this assay, from the lowest: compound 3; then compounds 1 and 4 (each within the scatter of the next); then compound 2.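

In this assay, 3-phenoxypropyl in place of benzoyl gives no change at the digits printed from compound 1 to compound 4 (within the scatter). This shows that, at this position on the ester side chain, the double bond that benzoyl carries outside its aromatic ring is not needed to keep the number low, and that a group with more heavy atoms is accepted here. Nothing available explains why the two groups match. Still open, going by these compounds, is whether an amine or a carboxylic acid in place of benzoyl would give a similar number, and whether a plain hexyl chain with no aromatic ring would do so.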